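Removing the Pyrazole Carbamate: Expected Exposure of Compound 4

The source may hold more compounds than are shown below. What is called first, only, known or untested is meant among the compounds shown, and "the series" means these compounds.

Compound 1 `CCN1CCN(c2cc(Nc3cc(C)nn3C(=O)C(C)(C)C)nc(N[C@H]3CCN(C(=O)c4ccc(Cl)cc4F)C3)n2)CC1` gives 59 nM in an ADME assay on the whole organism (Mus musculus, strain ICR) for pharmacokinetics, read by LC-MS, with a stated time of 24 h, at a dose of 10 mg/kg by the oral route; on this read-out higher numbers stand for higher exposure at the dose given and lower numbers for lower exposure. Compound 2 `CCN1CCN(c2cc(Nc3cc(C)nn3C(=O)OC(C)(C)C)nc(N[C@H]3CCN(C(=O)c4ccc(Cl)cc4F)C3)n2)CC1` gives 1100 nM. Compound 3 `CCOC(=O)n1nc(C)cc1Nc1cc(N2CCN(CC)CC2)nc(N[C@H]2CCN(C(=O)c3ccc(Cl)cc3F)C2)n1` gives 1820 nM.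

Compound 3 holds the highest number of the three in this assay, though its gap to compound 2 lies within the scatter (a 1.7-fold higher number from compound 2 to compound 3 (0.22 log units; within the scatter)), while the gap from compound 1 is large (a 31-fold higher number from compound 1 to compound 3 (1.49 log units; beyond the scatter)). Compound 4 `CCN1CCN(c2cc(Nc3cc(C)[nH]n3)nc(N[C@H]3CCN(C(=O)c4ccc(Cl)cc4F)C3)n2)CC1` differs from compound 3 by 5-methyl-1H-pyrazol-3-yl in place of 1-(ethoxycarbonyl)-3-methyl-1H-pyrazol-5-yl on a nitrogen on an aromatic ring. Within the data shown here, none of the measured steps covers removing the whole group from that nitrogen; they only exchange one carbonyl substituent for another, as in a 19-fold higher number from compound 1 to compound 2 (1.27 log units; beyond the scatter) and a 31-fold higher number from compound 1 to compound 3 (1.49 log units; beyond the scatter). The expected step in this assay is therefore uncertain, put at a 2.3-fold lower number from compound 3 to compound 4 (0.36 log units; beyond the scatter). Compound 4 is estimated at 800 nM in this assay, with a range from 200 nM to 3000 nM.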

Compound 4, maximal plasma concentration: 748 nM
Beside the measured number, compound 4's estimate is 1.1-fold (0.03 log units) above it; low and high end bracket the measured number.
By their numbers in this assay, from the lowest: compound 1; then compounds 4, 2 and 3 (each within the scatter of the next, the first and the last beyond it).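

In this assay, exposure survives the complete loss of the carbonyl substituent: 5-methyl-1H-pyrazol-3-yl brings a 2.4-fold lower number from compound 3 to compound 4 (0.39 log units; beyond the scatter), a modest drop, yet also a 13-fold higher number from compound 1 to compound 4 (1.10 log units; beyond the scatter), a large rise. Among these compounds, then, a carbonyl substituent can raise or lower the number against the bare pyrazole, depending on what it carries. Nothing shown explains either step. Still open, going by these compounds, is how a small acetyl group or a plain methyl group would behave in place of these carbonyl substituents.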